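The compounds below may be only part of what the source reports. "The series", "measured", "known", "first", "only" and "open" are said of these compounds alone.

Compound 1 `Cc1c[nH]cc1C(=O)O` gives 50% in an assay on cells for inhibition of Palmitoleoyl-protein carboxylesterase NOTUM variant C330S (Homo sapiens), read by fluorescence, with a stated time of 40 min, tested at 100 uM; a lower number here means less inhibition, a higher number more inhibition at the concentration tested (going by the name of the read-out). Compound 2 `Cc1cc(C(=O)O)c[nH]1` gives 50% in this assay, level with compound 1 within the scatter. For compound 3 `O=C(O)c1c[nH]c(C(F)(F)F)c1` the result in this assay is a limit, < 20% (the limit of < 20% in this assay, at which 1 of the 3 values shown sits). Among the measured compounds shown here, the step of a number at least 30 percentage points lower from compound 2 to compound 3 (beyond the scatter) is the only measured step. Compound 4 `Cc1c[nH]c(C)c1C(=O)O` differs from compound 1 by methyl in place of hydrogen on an aromatic carbon. For the measured compounds named here, no measured step shows methyl in place of hydrogen, and the trifluoromethyl step from compound 2 to compound 3 is a different change; compounds 1 and 2 show that the two methyl placements measured sit within the scatter of each other. Compound 4 is therefore expected near compound 1, with no change at the digits printed from compound 1 to compound 4 (within the scatter) as the estimated step, giving 50% between 30% and 70%.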

Compound 4, a percentage reported as inhibition, at one concentration (the size of the read-out at that concentration, not a potency): 50%
For compound 4 middle estimate and measured number coincide at the digits printed, and the stated range covers the measured number.
By their numbers in this assay, from the lowest: compounds 1, 2 and 4 (each within the scatter of the next). At a limit, below all of these: compound 3.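

This position, next to the ring nitrogen and next to the ring atom that bears a carboxy group, takes methyl in place of hydrogen with no change at the digits printed from compound 1 to compound 4 (within the scatter) in this assay. Among the compounds shown here, this is the first measured step in which methyl enters, and the first change at this position. Compound 4 stays clear of the limit that compound 3 sits at, so the step can be read as a number: the limit of < 20% in this assay, at which 1 of the 4 values shown sits.

On these data alone, whether this position also accepts a longer chain, an amine or a chlorine remains open. Also open, as far as these compounds go, is whether the shared core keeps any inhibition with an amide in place of the carboxylic acid.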